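Ester pairs on a shared dihydropyridine core

The source may hold more compounds than are shown below. What is called first, only, known or untested is meant among the compounds shown, and "the series" means these compounds.

Three compounds share a core and differ only in the two ester groups. Compound 1 `CCCOC(=O)C1=C(C)NC(C)=C(C(=O)OC)C1c1csc(-c2ccc(Cl)cc2)n1` gives 5920 nM in an assay on isolated protein for antagonist activity at Voltage-dependent L-type calcium channel subunit alpha-1C (Cavia porcellus), with a stated time of 15 min; a higher number here means a weaker inhibitor, a lower number a stronger inhibitor. Compound 2 `CCCOC(=O)C1=C(C)NC(C)=C(C(=O)OCC)C1c1csc(-c2ccc(Cl)cc2)n1` carries methyl in place of hydrogen on a saturated chain carbon bound to an oxygen next to a carbonyl group and gives 4090 nM in this assay; the step is a 1.4-fold lower number from compound 1 to compound 2 (0.16 log units; within the scatter). Compound 3 `COC(=O)C1=C(C)NC(C)=C(C(=O)OCCc2ccccc2)C1c1csc(-c2ccc(Cl)cc2)n1` differs from compound 1 by phenyl in place of methyl on a saturated chain carbon, two bonds along the chain from an oxygen next to a carbonyl group, and in this assay compound 3 gives 10200 nM, a step of a 1.7-fold higher number from compound 1 to compound 3 (0.24 log units; within the scatter). Compounds 2 and 3 were not compared directly, but their two values sit a little further apart than the other pairs.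

Compound 4 `CCOC(=O)C1=C(C)NC(C)=C(C(=O)OCCc2ccccc2)C1c1csc(-c2ccc(Cl)cc2)n1` is not yet measured. It differs from compound 3 by methyl in place of hydrogen on a saturated chain carbon bound to an oxygen next to a carbonyl group, the same change that separates compound 1 from compound 2, occurring twice among these compounds. Since that change gave a 1.4-fold lower number from compound 1 to compound 2 (0.16 log units; within the scatter), a step of similar size is expected from compound 3 to compound 4, namely a 1.4-fold lower number from compound 3 to compound 4 (0.15 log units; within the scatter). On that basis compound 4 is estimated at 7300 nM in this assay, with a likely range from 3500 nM to 16000 nM.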

Compound 4, half-maximal inhibitory concentration: 12100 nM
The estimate for compound 4 lay 1.7-fold (0.22 log units) below the measured number; the measured number falls inside the stated range.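

The methyl change gives a 1.2-fold higher number from compound 3 to compound 4 (0.07 log units; within the scatter) in this assay, and set beside its earlier occurrence, it shows no difference between the two cores that can be told from scatter: the same change on two cores in this assay, a 1.4-fold lower number (0.16 log units; within the scatter) from compound 1 to compound 2 and a 1.2-fold higher number (0.07 log units; within the scatter) from compound 3 to compound 4, 1.7-fold (0.23 log units) apart, within the scatter of two such steps

The change from methyl to phenyl gives a 3.0-fold higher number from compound 2 to compound 4 (0.47 log units; beyond the scatter), which lies beyond the scatter on its own, while its earlier occurrence does not, yet the two steps still cannot be told apart: the same change on two cores in this assay, a 1.7-fold higher number (0.24 log units; within the scatter) from compound 1 to compound 3 and a 3.0-fold higher number (0.47 log units; beyond the scatter) from compound 2 to compound 4, 1.7-fold (0.23 log units) apart, within the scatter of two such steps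

Within these four compounds, both changes therefore carry from one core to the other as far as the data can resolve, but each comparison rests on a single pair of small steps, so this does not show that the steps are exactly equal or that they would hold for other esters.

The compounds shown vary only simple alkyl and phenyl-bearing ester chains on the shared core. They leave open whether the same steps would hold with an amine or a carboxylic acid at the end of the ester chain, or with a longer chain such as butyl.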